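Methoxy in Place of Chloro on a Urea Cytotoxicity Series

This account rests on a few compounds, and the source may have more. Where it says the series, first, only, none or still open, it means among the compounds named here.

Measured in an ADME assay on BJ cells (Homo sapiens) for cytotoxicity, with a stated time of 72 h; a lower number here means that less compound is needed, a higher number that more compound is needed for the effect:
Compound 1 `Cc1cc(NC(=O)Nc2ccc(Cl)c(Cl)c2)c2ccccc2n1` gives 23000 nM.
Compound 2 `COc1ccc(NC(=O)Nc2cc(C)nc3ccccc23)cc1Cl` gives 23000 nM.
Compound 3 `Cc1cc(NC(=O)Nc2ccc(Cl)cc2)c2ccccc2n1` gives > 25000 nM, which is a limit of this assay and not a number.

Compound 1 and compound 2 differ by one change, (methoxy in place of chloro on an aromatic carbon), and the outcome is no change at the digits printed from compound 1 to compound 2 (within the scatter). Compound 1 and compound 3 differ by hydrogen in place of chloro on an aromatic carbon, and that step is an at least 1.0-fold higher number from compound 1 to compound 3 (0.03 log units; that floor lies within the scatter); compound 3 sits at the limit (the limit of > 25000 nM in this assay, at which 1 of the 3 values shown sits).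

Compound 4 `COc1ccc(NC(=O)Nc2cc(C)nc3ccccc23)cc1` has not yet been measured in this assay. It differs from compound 3 by methoxy in place of chloro on an aromatic carbon. For the measured compounds named here, this is the same kind of change as the one from compound 1 to compound 2, but not the same: in the earlier pair the place was also ortho to a chloro group, whereas in compound 3 it is only para to a large group.

The step from compound 3 to compound 4 is expected to be small, as in no change at the digits printed from compound 1 to compound 2 (within the scatter). Compound 4 is therefore estimated at 30000 nM, between 15000 nM and 60000 nM, a step that the limit leaves unreadable from compound 3 to compound 4, with a fair chance that only a limit is reported.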

Compound 4, half-maximal effective concentration: > 25000 nM
Compound 4 was reported as a limit (the forecaster's own chance of this, stated with the estimate: 65%); the middle value does not contradict the limit.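

Hydrogen in place of chloro on an aromatic carbon has now been followed on two cores in this assay, and on the core bearing the methoxy group the result is an at least 1.0-fold higher number from compound 2 to compound 4 (0.03 log units; that floor lies within the scatter). Set beside the same change on the other core, the comparison reads: the same change on two cores in this assay, an at least 1.0-fold higher number (0.03 log units; that floor lies within the scatter) from compound 1 to compound 3 and an at least 1.0-fold higher number (0.03 log units; that floor lies within the scatter) from compound 2 to compound 4; the limit leaves it open whether they differ. This shows that neither core gives a readable step beyond the scatter, but it does not show that the change has the same size on both cores, and the step between compound 3 and compound 4 cannot be read, since both values are limits and not numbers: the limit of > 25000 nM in this assay, at which 2 of the 4 values shown sit.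

On these data alone, the true values of compound 3 and compound 4 stay open, and with them any real difference between the two cores. Also open, as far as these compounds go, is whether an amine or a carboxylic acid on the same aromatic carbon would give a number rather than a limit in this assay.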